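The compounds below may be only part of what the source reports. "The series", "measured", "known", "first", "only" and "open" are said of these compounds alone.

Measured in an ADME assay on HepG2 2.2.15 cells (Homo sapiens) for cytotoxicity, read by luminescence, with a stated time of 3 days; a lower number here means that less compound is tolerated, a higher number that more compound is tolerated:
- compound 1 `O=C(Nc1ccc(F)c(Cl)c1)c1ccc(F)c(S(=O)(=O)N2CCSCC(O)C2)c1`: 19000 nM
- compound 2 `O=C(Nc1ccc(F)c(Cl)c1)c1ccc(F)c(S(=O)(=O)N2CCCC(O)CC2)c1`: 29000 nM

Compound 2, at 29000 nM, stands within the scatter of compound 1, so the two values do not separate. The next structure is compound 3 `CN1CCCN(S(=O)(=O)c2cc(C(=O)Nc3ccc(F)c(Cl)c3)ccc2F)CC1=O`, which carries 4-methyl-3-oxo-1,4-diazepan-1-yl in place of 4-hydroxyazepan-1-yl on a sulfonyl sulfur.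

For the measured compounds named here, only one measured step bears on this change. It also swaps one seven-membered ring on the sulfonyl sulfur for another: a 1.5-fold higher number from compound 1 to compound 2 (0.18 log units; within the scatter). That step lies within the scatter. Going by the values given here, no measured compound carries a ring of the kind found in compound 3, so this support is thin. No step beyond the scatter is therefore expected in this assay, and the estimated step is a 1.0-fold lower number from compound 2 to compound 3 (0.02 log units; within the scatter). Compound 3 is estimated at 28000 nM, with an expected range of 12000 nM to 65000 nM.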

Compound 3, half-maximal cytotoxic concentration: > 100000 nM
Compound 3 was reported as a limit; the forecaster's own chance of this, stated with the estimate: 30%; middle value at least 3.5-fold (0.55 log units) from the limit.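

In this assay, the place on the sulfonyl sulfur now shows a change beyond the scatter: 4-methyl-3-oxo-1,4-diazepan-1-yl in place of 4-hydroxyazepan-1-yl gives an at least 3.4-fold higher number from compound 2 to compound 3 (0.53 log units; beyond the scatter), and the same group against the other seven-membered ring with 2 hetero atoms gives an at least 5.2-fold higher number from compound 1 to compound 3 (0.72 log units; beyond the scatter). For the compounds shown here, the earlier pair did not separate, so this is the first sign that the group at this place can move the read-out. The full size of both steps stays unread because compound 3 stands at a limit of the assay: the limit of > 100000 nM in this assay, at which 1 of the 3 values shown sits.

The compounds shown leave open whether the 4-methyl or the 3-oxo part of the group carries the step. They also leave open whether morpholine or an open-chain dimethylamino group on the sulfonyl sulfur would stand with compound 3 or with compound 2.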